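Alkyl variation on the ring nitrogen: toward compound 3

A few compounds are considered here, and "the series" means these few. Any claim that something is new, unique, unknown or untested is made for them only; others in the source may bear on it.

Compound 1 `CC(C)n1cnc2c(N)ncnc21`; in an assay on CHO cells for displacement of a labelled ligand from adenosine receptor A3 (Homo sapiens) (a higher number here means a weaker inhibitor, a lower number a stronger inhibitor), compound 1 gives > 100000 nM, a limit.
Compound 2 `CC(C)Cn1cnc2c(N)ncnc21`; in this assay compound 2 gives > 100000 nM, a limit.

Compound 2 stands at a limit of this assay and no number is attached to it. Within the data shown here, the one measured step, a step that the two limits leave unreadable from compound 1 to compound 2, has no readable size because the limit of > 100000 nM in this assay, at which 2 of the 2 values shown sit, holds both values shown. Compound 3 `Nc1ncnc2c1ncn2C1CCC1` differs from compound 2 by cyclobutyl in place of isobutyl on an aromatic nitrogen. Among the measured compounds shown here, no measured step bears on this change with a readable magnitude, so neither direction nor size can be taken from the series; the only guidance is that both small alkyl groups on this nitrogen so far sit at the limit. Compound 3 is therefore expected to remain at or near that limit in this assay, with an estimate of 100000 nM and a range from 20000 nM to 300000 nM. The expected step of a number no higher from compound 2 to compound 3 (the limit leaves the size open) is an estimate of no change beyond the scatter.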

Compound 3, inhibition constant: 33000 nM
For compound 3 the middle estimate is 3.0-fold (0.48 log units) above the measured one; the measured number falls inside the stated range.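

In this assay, the position on the aromatic nitrogen now gives a first readable value: cyclobutyl, with one four-membered non-aromatic ring of carbon only, gives an at least 3.0-fold lower number from compound 2 to compound 3 (0.48 log units; beyond the scatter), although the entering and leaving groups have the same count of heavy atoms. Against the isopropyl group, the change gives an at least 3.0-fold lower number from compound 1 to compound 3 (0.48 log units; beyond the scatter). Both sizes are open on one side because the values of compound 1 and compound 2 are limits: the limit of > 100000 nM in this assay, at which 2 of the 3 values shown sit.

Whether the ring itself accounts for this step cannot be separated with one cyclic example, so cyclopropyl, cyclopentyl and cyclohexyl on the same nitrogen remain open. Also open, from the compounds shown here alone, is whether a benzyl group there would carry the series further from the limit, and how any such group would behave with other changes on the shared core.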